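A Methyl Step Carried Onto a Fluorinated Core

The source may report more compounds than this note shows. Statements on the series, on what has been measured and on what is new or still open speak of the compounds shown alone.

Compound 1 `CC/C=C\C(=O)Nc1cc(Nc2nccc(-c3cn(C)c4ccccc34)n2)c(OC)cc1N(C)CCN(C)C` and compound 2 `CC/C=C\C(=O)Nc1cc(Nc2nc(C)cc(-c3cn(C)c4ccccc34)n2)c(OC)cc1N(C)CCN(C)C` share one core and are joined by the change (methyl in place of hydrogen on an aromatic carbon). In a functional assay on NCI-H1975 cells (Homo sapiens) for antiproliferative activity, read by MTT assay, with a stated time of 72 h (on this read-out higher numbers stand for weaker inhibition and lower numbers for stronger inhibition), compound 1 gives 3860 nM, and compound 2 gives 1990 nM. The step of a 1.9-fold lower number from compound 1 to compound 2 (0.29 log units; within the scatter) stays within the scatter. Compound 3 `C=CC(=O)Nc1cc(Nc2nccc(-c3cn(C)c4ccc(F)cc34)n2)c(OC)cc1N(C)CCN(C)C` rests on a different core; the difference between the two cores is not broken down here. In this assay compound 3 gives 254 nM, the lowest number of the three. Compound 4 `C=CC(=O)Nc1cc(Nc2nc(C)cc(-c3cn(C)c4ccc(F)cc34)n2)c(OC)cc1N(C)CCN(C)C` follows from compound 3 by methyl in place of hydrogen on an aromatic carbon, the same kind of change, although here the methyl sits meta to a 5-fluoro-1-methyl-1H-indol-3-yl group rather than a 1-methyl-1H-indol-3-yl group. Because the earlier step of a 1.9-fold lower number from compound 1 to compound 2 (0.29 log units; within the scatter) stayed within the scatter, compound 4 is expected to move by a 1.6-fold lower number from compound 3 to compound 4 (0.20 log units; within the scatter). The estimate for compound 4 in this assay is 160 nM, between 60 nM and 420 nM.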

Compound 4, half-maximal inhibitory concentration: 3830 nM
For compound 4 the middle estimate is 24-fold (1.38 log units) below the measured one; measured number outside the range, above it.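

Moved onto the core of compound 3, the methyl in place of hydrogen on an aromatic carbon gave, in this assay, a 15-fold higher number from compound 3 to compound 4 (1.18 log units; beyond the scatter), a large step towards weaker inhibition. The change therefore did not carry over unchanged between the two cores: the same change on two cores in this assay, a 1.9-fold lower number (0.29 log units; within the scatter) from compound 1 to compound 2 and a 15-fold higher number (1.18 log units; beyond the scatter) from compound 3 to compound 4, 29-fold (1.47 log units) apart, beyond the scatter of two such steps

This shows that the effect of the methyl depends on the core that carries it, but not which difference between the cores is responsible, and two pairs set no rule for the series. The compounds shown leave open whether the fluoro group or the amide chain decides the outcome, and how an ethyl or a methoxy group in place of that methyl would behave on either core.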